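A Triazole Substituent Change Followed in a Cytotoxicity Read-out

This account rests on a few compounds, and the source may have more. Where it says the series, first, only, none or still open, it means among the compounds named here.

Of the compounds shown here, three built on one shared core have been measured in an ADME assay on HEK293 cells (Homo sapiens) for cytotoxicity, read by sulforhodamine B assay, with a stated time of 48 h, tested at 10 uM; on this read-out lower numbers stand for less inhibition and higher numbers for more inhibition at the one concentration tested (going by the name of the read-out). Compound 1 `CCCCCCCc1cn(C(c2ccccc2)c2cc3cc(Br)ccc3nc2OC)nn1` gives 0.17% in this assay. Compound 2 `CCOC(=O)c1cn(C(c2ccccc2)c2cc3cc(Br)ccc3nc2OC)nn1` gives 2%. Compound 3 `CCCc1cn(C(c2ccccc2)c2cc3cc(Br)ccc3nc2OC)nn1` gives 0.85%. Among these three numbers compound 3 stands second highest; its nearest neighbour is compound 1 and its furthest is compound 2, yet every step between them stays within the scatter: a number 1.8 percentage points higher from compound 1 to compound 2 (within the scatter), a number 0.7 percentage points higher from compound 1 to compound 3 (within the scatter) and a number 1.2 percentage points lower from compound 2 to compound 3 (within the scatter).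

Compound 4 `COc1nc2ccc(Br)cc2cc1C(c1ccccc1)n1cc(-c2ccc(OC(F)(F)F)cc2)nn1` differs from compound 3 in one place: 4-(trifluoromethoxy)phenyl in place of propyl on an aromatic carbon. Among the compounds with values here, none of the measured steps brings an aromatic ring onto that carbon, so their bearing is indirect. What they do show is that putting ethoxycarbonyl in place of heptyl, and hydrogen in place of butyl on the chain, each left this assay essentially unmoved, with all three values sitting close together near the bottom of the scale. The step of a number 2.2 percentage points higher from compound 3 to compound 4 (within the scatter) is therefore expected to remain within the scatter, with at most a slight lean toward a higher number. Compound 4 is estimated at 3% in this assay, with a range from -5% to 14%.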

Compound 4, a percentage reported as inhibition, at one concentration (the size of the read-out at that concentration, not a potency): 5.8%
For compound 4 the middle estimate is 2.8 percentage points below the measured one; measured number inside the range.
By their numbers in this assay, from the lowest: compounds 1, 3, 2 and 4 (each within the scatter of the next).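

Compound 4 is the only one of the four with an aromatic ring on this aromatic carbon of the five-membered aromatic ring, and in this assay the steps of a number 5 percentage points higher from compound 3 to compound 4 (within the scatter) and a number 3.8 percentage points higher from compound 2 to compound 4 (within the scatter) and a number 5.6 percentage points higher from compound 1 to compound 4 (within the scatter) all remain inside the usual variation of the read-out. Within the data shown here, the position therefore accepts 4-(trifluoromethoxy)phenyl, with its 11 heavy atoms against the 3 of propyl, without compound 4 being separated from the compounds carrying propyl, heptyl or ethoxycarbonyl, a wider change of group than any of the earlier steps had covered. Nothing available bears on how these numbers arise, so the result can be recorded but not explained.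

What the compounds shown leave open is whether an amine, a carboxylic acid or a plain phenyl ring on this carbon would give a number that stands clear of the others in this cytotoxicity read-out. They also leave open how far the 4-(trifluoromethoxy)phenyl group itself matters, since a single tested concentration and steps inside the scatter cannot separate its contribution from that of any other group at this place.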